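A Pyrimidine in Place of a Pyridine

This account rests on a few compounds, and the source may have more. Where it says the series, first, only, none or still open, it means among the compounds named here.

Compound 2 `Cc1cncc(-c2noc([C@H](C)NC(=O)c3cc(C(F)(F)F)nn3C)n2)c1` and compound 1 `Cc1cccc(-c2noc(C(C)NC(=O)c3cc(C4CC4)nn3C)n2)c1` share a core but are not linked by a single change. In an assay on T-REx-293 cells for inhibition of potassium channel subfamily T member 1 (Homo sapiens), read by patch clamp (on this read-out lower numbers stand for stronger inhibition and higher numbers for weaker inhibition), compound 2 gives 1370 nM, and compound 1 gives 1880 nM; the two numbers lie within the scatter of each other, so neither stands apart. Compound 3 `Cc1cc(-c2noc([C@H](C)NC(=O)c3cc(C(F)(F)F)nn3C)n2)ncn1` has not been measured; it differs from compound 2 by 6-methylpyrimidin-4-yl in place of 5-methylpyridin-3-yl on an aromatic carbon. Among the measured compounds shown here, with no measured step of this kind to draw on, the change is expected to shift the number by little, if anything beyond the scatter, a 1.3-fold higher number from compound 2 to compound 3 (0.12 log units; within the scatter). Compound 3 is therefore estimated at 1800 nM in this assay, within 700 nM to 4500 nM.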

Compound 3, half-maximal inhibitory concentration: 1410 nM
Beside the measured number, compound 3's estimate is 1.3-fold (0.11 log units) above it, within the range that was stated.
By their numbers in this assay, from the lowest: compounds 2, 3 and 1 (each within the scatter of the next).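

Among the compounds shown here, the exchange of 5-methylpyridin-3-yl for 6-methylpyrimidin-4-yl is the first single change that can be read at this place on the shared core, and in this assay it gives a 1.0-fold higher number from compound 2 to compound 3 (0.01 log units; within the scatter). A second ring nitrogen, counted as a second hydrogen-bond acceptor, is thus taken up here without a step beyond the scatter. Nothing at hand accounts for this result.

Still open, as far as these compounds go, is whether an amine or a carboxylic acid on this six-membered ring would leave the number equally unmoved. From the compounds shown here alone, a simple phenyl ring or a morpholine at this place remains equally open.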